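The source may hold more compounds than are shown below. What is called first, only, known or untested is meant among the compounds shown, and "the series" means these compounds.

Compound 1 `CC1CC/C(=N\Nc2ccc(F)cc2)c2ncc(C(=O)O)c(=O)n21`: > 1000 umol/kg
Compound 2 `COc1ccc(N/N=C2\CCC(C)n3c2ncc(C(=O)O)c3=O)cc1`: 7.6 umol/kg

Both compounds share one core and differ only in the group carried on the aromatic ring at the far end. In a functional assay on the whole organism for inhibition, with Rattus norvegicus as the target (a higher number here means that more compound is needed for the effect, a lower number that less compound is needed), compound 1 reaches only (the limit of > 1000 umol/kg in this assay, at which 1 of the 2 values shown sits), which is a limit of the assay and not a number. In this assay compound 2 gives 7.6 umol/kg. The move between them is an at least 130-fold lower number from compound 1 to compound 2 (2.11 log units; beyond the scatter), brought about by methoxy in place of fluoro on an aromatic carbon. Among the compounds with values here, compound 2 therefore holds the only measured number here; the other value is a limit.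

Compound 3 `CC1CC/C(=N\Nc2ccc([N+](=O)[O-])cc2)c2ncc(C(=O)O)c(=O)n21` has not yet been measured. It differs from compound 2 by nitro in place of methoxy on an aromatic carbon. Within the data shown here, no measured step swaps methoxy for nitro, so the sole guide is the step from compound 1 to compound 2, which shows that a single change on this carbon can shift the value greatly. A step of a 6.6-fold higher number from compound 2 to compound 3 (0.82 log units; beyond the scatter) toward a higher number is expected, with wide uncertainty. Compound 3 is estimated at 50 umol/kg, in the range 8 umol/kg to 500 umol/kg.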

Compound 3, dose for 50% inhibition: > 320 umol/kg
Compound 3: only a limit was reported; the forecaster's own chance of this, stated with the estimate: 25%; at least 6.4-fold (0.80 log units) between middle value and limit.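

Compound 3 gives no number in this assay, only a limit of the assay: the limit of > 320 umol/kg in this assay, at which 1 of the 3 values shown sits.

Even with that limit, putting nitro in place of methoxy on this aromatic carbon, para to a large group, can be read as an at least 42-fold higher number from compound 2 to compound 3 (1.62 log units; beyond the scatter). Methoxy is now the only one of the three groups on this carbon with a measured number, and the changes to fluoro and to nitro both end at a limit. The step between the fluoro and nitro compounds cannot be read, so these two groups cannot be put in order.

The compounds shown leave open whether methoxy stands alone at this carbon, or whether a related group such as ethoxy, a hydroxyl or an amine would also give a measured number in this assay. They also leave open what plain hydrogen on this carbon would give, a result that could help tell whether methoxy adds to the effect or whether fluoro and nitro take away from it.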